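This account rests on a few compounds, and the source may have more. Where it says the series, first, only, none or still open, it means among the compounds named here.

Of the compounds shown here, three built on one shared core have so far been tested in an ADME assay on HepG2 cells (Homo sapiens) for cytotoxicity, read by luminescence, CellTiter-Glo and ATP content, with a stated time of 72 h; on this read-out lower numbers stand for an effect already at smaller amounts and higher numbers for an effect only at larger amounts of compound. Compound 1 `COc1ccccc1Oc1ccc2c(NCCCNCc3ccco3)ccnc2c1` gives 6500 nM. Compound 2 `CC(C)Cc1ccc2c(NCCCNCc3ccco3)ccnc2c1` gives 16000 nM, and compound 3 `c1ccc(Oc2ccc3c(NCCCNCc4ccco4)ccnc3c2)cc1` gives 15200 nM. Among these three numbers compound 3 stands second highest; its value and that of compound 2 lie within the scatter of each other, whereas the step of a 2.3-fold higher number from compound 1 to compound 3 (0.37 log units; beyond the scatter) lies beyond it. Compound 4 `c1ccc(-c2ccc3c(NCCCNCc4ccco4)ccnc3c2)cc1` is the next to be measured. Its difference from compound 3 is phenyl in place of phenoxy on an aromatic carbon. The step that bears most on this change is a 1.1-fold lower number from compound 2 to compound 3 (0.02 log units; within the scatter), where one group on this same aromatic carbon gave way to another without the number moving. The remaining steps were only modest. One is a 2.5-fold higher number from compound 1 to compound 2 (0.39 log units; beyond the scatter). The other is a 2.3-fold higher number from compound 1 to compound 3 (0.37 log units; beyond the scatter). On that basis the step of a 1.0-fold lower number from compound 3 to compound 4 (0.01 log units; within the scatter) is expected to stay within the scatter. Compound 4 is therefore estimated at 15000 nM, with a likely range from 7000 nM to 32000 nM.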

Compound 4, half-maximal effective concentration: 5920 nM
The estimate for compound 4 lay 2.5-fold (0.40 log units) above the measured number; the measured number lies below the stated range.
By their numbers in this assay, from the lowest: compounds 4 and 1 (each within the scatter of the next); then compounds 3 and 2 (each within the scatter of the next).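

In this assay this aromatic carbon turns out not to be indifferent to its group: putting phenoxy in place of isobutyl left the number unmoved, yet removing only the linking oxygen of phenoxy to leave phenyl gives a 2.6-fold lower number from compound 3 to compound 4 (0.41 log units; beyond the scatter) as a modest shift. Phenyl in place of isobutyl tells the same story, with a 2.7-fold lower number from compound 2 to compound 4 (0.43 log units; beyond the scatter) as its step. Phenyl in place of 2-methoxyphenoxy, by contrast, gives a 1.1-fold lower number from compound 1 to compound 4 (0.04 log units; within the scatter) and so no real change, which means two quite different groups on this carbon can share one level.

On these data alone, whether an amine or a carboxylic acid on this carbon would stay at that level or sit with compound 2 remains open. Nothing available gives a cause for these shifts.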